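Swapping Benzyl for Cyclopentyl on a Weak Amide

A few compounds are considered here, and "the series" means these few. Any claim that something is new, unique, unknown or untested is made for them only; others in the source may bear on it.

Compound 1 `CCC(C)C(NC(=O)n1nnc2ccccc21)C(=O)NC(c1ccccc1)c1ccccc1`: 69300 nM
Compound 2 `CCC(C)C(NC(=O)n1nnc2ccccc21)C(=O)NCc1ccccc1`: > 100000 nM

In a functional assay on MIA PaCa-2 cells (Homo sapiens) for inhibition (a higher number here means a weaker inhibitor, a lower number a stronger inhibitor), compound 1 gives 69300 nM. Compound 2 reaches only the assay limit, > 100000 nM, so no number is known for it. The step of an at least 1.4-fold higher number from compound 1 to compound 2 (0.15 log units; that floor lies within the scatter) removed one phenyl. Compound 3 `CCC(C)C(NC(=O)n1nnc2ccccc21)C(=O)NC1CCCC1` carries cyclopentyl in place of benzyl on an amide-type nitrogen. Within the data shown here, only the step from compound 1 to compound 2 bears on this change, and it ends at the limit of > 100000 nM in this assay, at which 1 of the 2 values shown sits. Compound 3 is therefore expected to stay weak, with a step that the limit leaves unreadable from compound 2 to compound 3 meaning no shift beyond the scatter, and is estimated at 150000 nM (range 60000 nM to 400000 nM).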

Compound 3, half-maximal inhibitory concentration: >= 100000 nM
Compound 3 gave a limit, no number; the forecaster's own chance of this, stated with the estimate: 70%; the middle value lies beyond the limit too.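

Compound 2 and compound 3 both end at a limit rather than a number, and the step between them cannot be read. On these data alone, how strongly either inhibits, and whether cyclopentyl differs from benzyl here, stays open.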